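A few compounds are considered here, and "the series" means these few. Any claim that something is new, unique, unknown or untested is made for them only; others in the source may bear on it.

Compound 1, `CCNC(=O)c1cc(CC)sc1NC(=O)c1ccc([N+](=O)[O-])o1`: > 20000 nM
Compound 2, `CCCCNC(=O)c1cc(CC)sc1NC(=O)c1ccc([N+](=O)[O-])o1`: > 20000 nM

In an ADME assay on HeLa cells (Homo sapiens) for cytotoxicity, read by resazurin assay, with a stated time of 65 h (on this read-out lower numbers stand for an effect already at smaller amounts and higher numbers for an effect only at larger amounts of compound), compound 1 gives > 20000 nM, which is a limit of the assay rather than a measured number. Compound 2 gives > 20000 nM in this assay, again a limit. Both values sit at the limit of > 20000 nM in this assay, at which 2 of the 2 values shown sit. The step that the two limits leave unreadable from compound 1 to compound 2 therefore cannot be read in size or direction, and compound 2 stands only at a limit, with no number of its own.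

Compound 3, `CCc1cc(C(N)=O)c(NC(=O)c2ccc([N+](=O)[O-])o2)s1`, has not yet been measured in this assay. It differs from compound 2 by hydrogen in place of butyl on an amide-type nitrogen. For the measured compounds named here, the only measured step that touches the same amide-type nitrogen is the unreadable one from compound 1 to compound 2, so nothing among the measured compounds shows whether shortening or removing the group on that nitrogen moves the read-out at all.

With compound 2 at a limit and no readable step to lean on, compound 3 is expected to stay near that same limit, so the step that the limit leaves unreadable from compound 2 to compound 3 is an expectation of no change beyond the scatter. The estimate for compound 3 is 30000 nM, expected to lie between 12000 nM and 100000 nM.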

Compound 3, half-maximal effective concentration: > 20000 nM
Compound 3: no number, only a limit; the forecaster's own chance of this, stated with the estimate: 80%; the middle value is on the limit's open side.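

In this assay compound 3 gives > 20000 nM, again a limit and not a number. The steps among compound 1, compound 2 and compound 3 therefore cannot be read in size or direction: the limit of > 20000 nM in this assay, at which 3 of the 3 values shown sit. The compounds shown leave open whether the group on the amide-type nitrogen changes the read-out in this assay at all.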